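Solubility outlook after a phenyl substituent swap

This account rests on a few compounds, and the source may have more. Where it says the series, first, only, none or still open, it means among the compounds named here.

Three compounds sharing one core were examined in a physicochemical assay for solubility, in phosphate buffer, measured as kinetic solubility, at pH 7.4; on this read-out higher numbers stand for higher solubility and lower numbers for lower solubility. Going by the values given here, compound 1 `Cc1ccc(C)c(-c2nc(CN3CCC(C(=O)NCCCN4C[C@H](C)C[C@H](C)C4)CC3)c(C)o2)c1` gives 56.1 ug/mL, the only finite number among the three results. For compound 2 `Cc1ccccc1-c1nc(CN2CCC(C(=O)NCCCCN3C[C@H](C)C[C@H](C)C3)CC2)c(C)o1` the result is a limit of the assay, > 71 ug/mL. For compound 3 `Cc1ccccc1-c1nc(CN2CCC(C(=O)N3CCN(CCN(C)C)CC3)CC2)c(C)o1` the result is likewise a limit, > 67 ug/mL. One of the three results sits at the limit of > 67 ug/mL in this assay, at which 1 of the 3 values shown sits, and one at the limit of > 71 ug/mL in this assay, at which 1 of the 3 values shown sits. Compound 4 `COc1cccc(F)c1-c1nc(CN2CCC(C(=O)NCCCN3C[C@H](C)C[C@H](C)C3)CC2)c(C)o1` differs from compound 1 in one place: 2-fluoro-6-methoxyphenyl in place of 2,5-dimethylphenyl on an aromatic carbon. Among the compounds with values here, no measured pair in this set differs in a single place, so the size of this step has no precedent here. The step from compound 1 to compound 4 is expected to be small, at most a modest rise in this assay, estimated as a 1.2-fold higher number from compound 1 to compound 4 (0.10 log units; within the scatter). Compound 4 is estimated at 70 ug/mL, with a range from 40 ug/mL to 110 ug/mL.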

Compound 4, solubility: > 74 ug/mL
Compound 4: a limit, no number (the forecaster's own chance of this, stated with the estimate: 50%); at least 1.0-fold (0.02 log units) between middle value and limit.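

In this assay, going by these compounds alone, the replacement of 2,5-dimethylphenyl by 2-fluoro-6-methoxyphenyl gives the first step in this set that changes one place only, on the aromatic carbon of the five-membered ring: an at least 1.3-fold higher number from compound 1 to compound 4 (0.12 log units; that floor lies within the scatter). The step shows no fall on this read-out at this position. Compound 4 gives a limit and not a number, so the step is only a floor: the limit of > 74 ug/mL in this assay, at which 1 of the 4 values shown sits.

As far as these compounds go, how far compound 4 lies past its limit stays open. Also open, from the compounds shown here alone, is whether a carboxylic acid or a morpholine on the phenyl ring at this position would give a finite number.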